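The source may report more compounds than this note shows. Statements on the series, on what has been measured and on what is new or still open speak of the compounds shown alone.

Working notes on the thioether series.

The shared core carries a sulfur-linked substituent that varies across the set. Compound 1 `O=c1c2ccccc2[se]n1-c1nc(SCc2ccc(F)cc2)n[nH]1` gives 46100 nM in a functional assay on SMMC-7721 cells (Homo sapiens) for antiproliferative activity, read by CCK-8 assay, with a stated time of 48 h; on this read-out lower numbers stand for stronger inhibition and higher numbers for weaker inhibition. Compound 2 `Cc1ccccc1CSc1n[nH]c(-n2[se]c3ccccc3c2=O)n1` gives 36200 nM in this assay; the step of a 1.3-fold lower number from compound 1 to compound 2 (0.10 log units; within the scatter) is within the scatter. Compound 3 `CCCSc1n[nH]c(-n2[se]c3ccccc3c2=O)n1` gives 6020 nM in this assay and stands lowest of the three numbers, with a 7.7-fold lower number from compound 1 to compound 3 (0.88 log units; beyond the scatter) and a 6.0-fold lower number from compound 2 to compound 3 (0.78 log units; beyond the scatter) both beyond the scatter, so the small alkyl group on the chain carbon bound to sulfur reads as the more favourable choice among these three.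

Compound 4 `CCCCSc1n[nH]c(-n2[se]c3ccccc3c2=O)n1` is not yet measured. It differs from compound 3 by methyl in place of hydrogen on a saturated chain carbon, three bonds along the chain from a sulfur, which reads propyl to butyl. Within the data shown here, no measured step extends an alkyl chain by one carbon; the two steps beyond the scatter replace an aryl group by ethyl, which is a different kind of change. The expected step in this assay is therefore none beyond the scatter, a 1.2-fold lower number from compound 3 to compound 4 (0.08 log units; within the scatter). Compound 4 is estimated at 5000 nM, with a range of 2000 nM to 12000 nM.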

Compound 4, half-maximal inhibitory concentration: 16800 nM
For compound 4 the middle estimate is 3.4-fold (0.53 log units) below the measured one; the whole stated range lies below it.
By their numbers in this assay, from the lowest: compound 3; then compound 4; then compounds 2 and 1 (each within the scatter of the next).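

The one-carbon extension from propyl to butyl shows that this assay is not flat at this position: methyl in place of hydrogen on a saturated chain carbon, three bonds along the chain from a sulfur, gives a 2.8-fold higher number from compound 3 to compound 4 (0.45 log units; beyond the scatter) and so moves the number away from its lowest point in the set. Butyl still stands apart from both aryl groups, with a 2.2-fold lower number from compound 2 to compound 4 (0.33 log units; beyond the scatter) and a 2.7-fold lower number from compound 1 to compound 4 (0.44 log units; beyond the scatter) showing that part of the gain from the alkyl replacement survives the longer chain. Nothing available accounts for the rise from propyl to butyl.

Going by these compounds, two alkyl chains give a single step and no trend, so whether a pentyl chain raises the number further or an ethyl chain lowers it stays open. On these data alone, how a chain carrying an amine or a carboxylic acid would read also stays open.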